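The source may hold more compounds than are shown below. What is called first, only, known or untested is meant among the compounds shown, and "the series" means these compounds.

Compound 3 `COc1cc(-c2cc(-c3ccc(O)cc3O)nc(-c3ccccc3)n2)cc(OC)c1OC` gives the lowest number of the three measured compounds in a functional assay on MDA-MB-231 cells (Homo sapiens) for inhibition, read by MTT assay, with a stated time of 48 h (a lower number here means a stronger inhibitor, a higher number a weaker inhibitor), namely 810 nM. Compound 1 `COc1cc(-c2cc(-c3ccccc3)nc(-c3ccccc3)n2)cc(OC)c1OC` gives 5870 nM and compound 2 `COc1cc(-c2cc(-c3cccs3)nc(-c3ccccc3)n2)cc(OC)c1OC` gives 5110 nM; between them a 1.1-fold lower number from compound 1 to compound 2 (0.06 log units; within the scatter), whereas a 7.2-fold lower number from compound 1 to compound 3 (0.86 log units; beyond the scatter) and a 6.3-fold lower number from compound 2 to compound 3 (0.80 log units; beyond the scatter). Compound 4 `COc1cc(-c2cc(-c3ccc(C)cc3)nc(-c3ccccc3)n2)cc(OC)c1OC` differs from compound 3 in one place: 4-methylphenyl in place of 2,4-dihydroxyphenyl on an aromatic carbon. The step of a 7.2-fold lower number from compound 1 to compound 3 (0.86 log units; beyond the scatter) bears most directly on this change, that step having added the 2,4-dihydroxyphenyl that now leaves, and the 4-methylphenyl entering stands closer to the phenyl of compound 1 and the thiophen-2-yl of compound 2 than to it. A return toward those numbers is therefore expected. Compound 4 is estimated at 5000 nM, between 2000 nM and 12000 nM. The expected step is a 6.2-fold higher number from compound 3 to compound 4 (0.79 log units; beyond the scatter).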

Compound 4, half-maximal inhibitory concentration: 5110 nM
Compound 4: the middle estimate sits 1.0-fold (0.01 log units) below what was measured; low and high end bracket the measured number.
By their numbers in this assay, from the lowest: compound 3; then compounds 2, 4 and 1 (each within the scatter of the next).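

In this assay there is a 6.3-fold higher number from compound 3 to compound 4 (0.80 log units; beyond the scatter) when 4-methylphenyl replaces 2,4-dihydroxyphenyl, while the other changes give a 1.1-fold lower number from compound 1 to compound 4 (0.06 log units; within the scatter) and no change at the digits printed from compound 2 to compound 4 (within the scatter) at this position, so among these four compounds only 2,4-dihydroxyphenyl stands apart from phenyl, thiophen-2-yl and 4-methylphenyl. No evidence is available to explain this difference.
The compounds shown leave open whether both hydroxyl groups are needed or a single hydroxyl would give the same number. They also leave open how a methoxy group or an amine on that phenyl ring would compare.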